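A few compounds are considered here, and "the series" means these few. Any claim that something is new, unique, unknown or untested is made for them only; others in the source may bear on it.

Compound 1 (`Oc1ccc(CN(Cc2ccccc2)Cc2ccc(O)c3ncccc23)c2cccnc12`): < 0.5 uM (a limit)
Compound 2 (`Oc1ccc(CN(Cc2cc(C(F)(F)F)cc(C(F)(F)F)c2)Cc2ccc(O)c3ncccc23)c2cccnc12`): < 0.2 uM (a limit)
Compound 3 (`Oc1ccc(CN(Cc2cccc(I)c2)Cc2ccc(O)c3ncccc23)c2cccnc12`): 2 uM (a number)

All three compounds were tested in a functional assay on U-87MG ATCC cells (Homo sapiens) for antiproliferative activity, with a stated time of 3 days; on this read-out higher numbers stand for an effect only at larger amounts of compound and lower numbers for an effect already at smaller amounts. Among the compounds with values here, compound 3 at 2 uM gives the only actual number in the set. The other two results are limits. Compound 4 (`Oc1ccc(CN(CCN2CCCC2)Cc2ccc(O)c3ncccc23)c2cccnc12`) has not yet been measured. It carries 2-(pyrrolidin-1-yl)ethyl where compound 3 carries 3-iodobenzyl ((pyrrolidin-1-yl)methyl in place of 3-iodophenyl on a saturated chain carbon bound to an amine nitrogen) on the shared core. Within the data shown here, one measured step bears on this change (an at least 4.0-fold higher number from compound 1 to compound 3 (0.60 log units; beyond the scatter)) and lies beyond the scatter. That step is iodo in place of hydrogen on an aromatic carbon, and compound 4 has no iodo. Among the measured compounds shown here, no measured step covers the entering (pyrrolidin-1-yl)methyl, so the expectation is loose: a modest move to a lower number in this assay rather than no change. The estimated step (a 2.5-fold lower number from compound 3 to compound 4 (0.40 log units; beyond the scatter)) is of that modest size. For compound 4 the expected value is 0.8 uM in an estimated range from 0.2 uM to 4 uM as its likely span.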

Compound 4, concentration for half-maximal effect: 0.2 uM
Compound 4: the middle estimate sits 4.0-fold (0.60 log units) above what was measured, and the stated range covers the measured number.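

Compounds 1 to 3 all carry a benzyl group at this place, so they showed only changes on that aromatic ring. Compound 4 shows that in this assay the whole aromatic ring can give way to a non-aromatic amine-bearing chain without loss, with a 10-fold lower number from compound 3 to compound 4 (1.00 log units; beyond the scatter), the largest readable step in the set. The comparison with the unsubstituted benzyl compound cannot be read, since compound 1 is recorded only as a limit: the limit of < 0.5 uM in this assay, at which 1 of the 4 values shown sits.

Going by these compounds, whether 2-(pyrrolidin-1-yl)ethyl matches or falls short of plain benzyl therefore stays open, and compound 2, likewise recorded only as a limit, gives no further reference: the limit of < 0.2 uM in this assay, at which 1 of the 4 values shown sits. Also open is how a piperidine, a morpholine, a dimethylamino group or a longer chain to the pyrrolidine would read at this place.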